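The source may hold more compounds than are shown below. What is called first, only, known or untested is meant among the compounds shown, and "the series" means these compounds.

Measured compounds and their values in a functional assay on 1321-N1 cells for agonist activity at Free fatty acid receptor 1 (Homo sapiens), read by calcium flux, with a stated time of 0.4 s; on this read-out lower numbers stand for smaller maximal responses and higher numbers for larger maximal responses:
Compound 1 `O=C(O)CCc1ccc(C#CC2CCCC2)cc1` gives 94%.
Compound 2 `C/C=C(/C)C#Cc1ccc(CCC(=O)O)c(F)c1` gives 103%.
Compound 3 `C/C=C\C#Cc1ccc(CCC(=O)O)c(F)c1` gives 91%.

Compound 1 sits close to both of its neighbours in this assay: its gap to compound 3 and its gap to compound 2 are each within the usual scatter, so the three values cannot be ordered with confidence. Among the compounds with values here, the only step beyond the scatter is a number 12 percentage points lower from compound 2 to compound 3 (beyond the scatter), a change on a triple-bonded carbon.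

Compound 4 `O=C(O)CCc1ccc(C#CC2CC2)cc1` has not been measured. It differs from compound 1 by cyclopropyl in place of cyclopentyl on a triple-bonded carbon. The change is again a smaller group on a triple-bonded carbon, as in the step from compound 2 to compound 3, which gave a modest drop. Within the data shown here, that single step is the only guide, and it is taken only loosely. A modest fall in this assay is therefore expected for compound 4, about a number 9 percentage points lower from compound 1 to compound 4 (within the scatter). The estimated value for compound 4 is 85%, with a range from 70% to 100%.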

Compound 4, largest response reached (reported as efficacy), in percent of the reference or control that the assay uses: 128%
Estimate against measurement, compound 4: 43 percentage points below; measured number outside the range, above it.
By their numbers in this assay, from the lowest: compounds 3, 1 and 2 (each within the scatter of the next, the first and the last beyond it); then compound 4.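

Within the data shown here, at this position, on a triple-bonded carbon, the ring carried there has a much larger effect than the earlier compounds showed: in this assay, the change from cyclopentyl to cyclopropyl gives a number 34 percentage points higher from compound 1 to compound 4 (beyond the scatter). A smaller group here therefore need not lower the maximal response, since the loss of heavy atoms in this step goes with a rise, whereas the smaller group in a number 12 percentage points lower from compound 2 to compound 3 (beyond the scatter) goes with a fall, so group size alone does not set the direction across these two pairs. Nothing available explains the rise seen with cyclopropyl.

The compounds shown leave open how cyclobutyl or an open-chain group such as tert-butyl would read on this carbon, and so whether cyclopropyl is unusual or part of a trend. They also leave open whether cyclopropyl would give a similar rise on the core of compound 2.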